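Lengthening the Acid Chain on a Diaryl Pyridine Core

The compounds below may be only part of what the source reports. "The series", "measured", "known", "first", "only" and "open" are said of these compounds alone.

Of the compounds shown here, three sharing one core have been tested in an assay on cell membranes from spleen (Cavia porcellus) for binding affinity to leukotriene B4 receptor 1 (Homo sapiens); a lower number here means a stronger inhibitor, a higher number a weaker inhibitor. Compound 1 `COC(=O)CCCCCOc1cc(-c2ccccc2)cc(-c2ccccc2)n1` gives 40 nM. Compound 2 `O=C(O)CCCOc1cc(-c2ccccc2)cc(-c2ccccc2)n1` gives 300 nM. Compound 3 `O=C(O)CCCCCOc1cc(-c2ccccc2)cc(-c2ccc(F)cc2)n1` gives 30 nM. Among these three numbers compound 2 stands highest, meaning it is the weakest inhibitor of the set, and the measured step from compound 1 to compound 2 reads a 7.5-fold higher number from compound 1 to compound 2 (0.88 log units; beyond the scatter).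

Compound 4 `O=C(O)CCCCCOc1cc(-c2ccccc2)cc(-c2ccccc2)n1` differs from compound 2 in one place: 2-carboxyethyl in place of carboxy on a saturated chain carbon, three bonds along the chain from an oxygen on an aromatic ring. Among the measured compounds shown here, the one measured step that bears on this change is a 7.5-fold higher number from compound 1 to compound 2 (0.88 log units; beyond the scatter), where shortening the chain and trading the ester for an acid went together with a weaker result. Compound 4 carries the same longer acid chain as compound 3, and compound 3 gives 30 nM, which sits well below compound 2. The expectation is therefore a clearly lower number for compound 4, with a step of about a 7.5-fold lower number from compound 2 to compound 4 (0.88 log units; beyond the scatter) expected. Compound 4 is estimated at 40 nM, with a likely range from 15 nM to 110 nM.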

Compound 4, half-maximal inhibitory concentration: 3 nM
Beside the measured number, compound 4's estimate is 13-fold (1.12 log units) above it, and the stated range ends above it.
By their numbers in this assay, from the lowest: compound 4; then compounds 3 and 1 (each within the scatter of the next); then compound 2.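

In this assay, with the acid kept on both sides, 2-carboxyethyl in place of carboxy gives a 100-fold lower number from compound 2 to compound 4 (2.00 log units; beyond the scatter) and so shows that chain length alone moves the number strongly at this position, whereas the earlier step changed the chain and the ester together. With the longer chain held fixed, hydrogen in place of methyl on the oxygen next to the carbonyl group gives a 13-fold lower number from compound 1 to compound 4 (1.12 log units; beyond the scatter) and so favours the free acid over its methyl ester. Hydrogen in place of fluoro on an aromatic carbon gives a 10-fold lower number from compound 3 to compound 4 (1.00 log units; beyond the scatter) as well, which leaves compound 4 the strongest inhibitor of the four.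

The compounds shown leave open whether a longer acid chain, or a tetrazole in place of the carboxylic acid, would keep this strength. No measurement given here explains why these changes shift the number.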